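This account rests on a few compounds, and the source may have more. Where it says the series, first, only, none or still open, it means among the compounds named here.

Going by the values given here, in a functional assay on K562 cells (Homo sapiens) for cytotoxicity, read by trypan blue exclusion, with a stated time of 96 h (on this read-out higher numbers stand for weaker inhibition and lower numbers for stronger inhibition), compound 2 (`COC(=O)C(Nc1cc(NS(=O)(=O)/C=C/c2c(OC)cc(OC)cc2OC)ccc1OC)c1ccc(Br)cc1`) gives 1000 nM, the lower of the two numbers so far, while compound 1 (`COC(=O)C(Nc1cc(NS(=O)(=O)/C=C/c2c(OC)cc(OC)cc2OC)ccc1OC)c1ccc(Cl)cc1`) gives 2500 nM. Compound 3 (`COc1cc(OC)c(/C=C/S(=O)(=O)Nc2ccc(OC)c(NC(C(=O)O)c3ccc(F)cc3)c2)c(OC)c1`) has carboxy(4-fluorophenyl)methyl in place of (4-bromophenyl)(methoxycarbonyl)methyl on a nitrogen on an aromatic ring: carboxy(4-fluorophenyl)methyl in place of (4-bromophenyl)(methoxycarbonyl)methyl. Among the compounds with values here, the only measured step, a 2.5-fold lower number from compound 1 to compound 2 (0.40 log units; beyond the scatter), bears on the halogen alone. Within the data shown here, no step from methoxycarbonyl to carboxy has been measured, so the direction is weakly held. In this assay, the expected step is modest and towards a higher number: a 2.5-fold higher number from compound 2 to compound 3 (0.40 log units; beyond the scatter). For compound 3 the estimated value is 2500 nM, with an expected range of 400 nM to 12000 nM.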

Compound 3, half-maximal inhibitory concentration: 20 nM
The estimate for compound 3 lay 130-fold (2.10 log units) above the measured number; the whole stated range lies above it.
By their numbers in this assay, from the lowest: compound 3; then compound 2; then compound 1.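

In this assay, the swap on the nitrogen gives a 50-fold lower number from compound 2 to compound 3 (1.70 log units; beyond the scatter) and a 130-fold lower number from compound 1 to compound 3 (2.10 log units; beyond the scatter). The earlier halogen step showed only a modest change, whereas this substituent can shift the number much further. No measured data here account for the size of these steps.

The carboxy group and the fluoro group enter together, so the compounds shown do not separate their contributions. Open, going by these compounds, are the 4-fluorophenyl methyl ester, the 4-bromophenyl carboxylic acid, and a primary amide in place of the carboxy group.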